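The compounds below may be only part of what the source reports. "The series", "measured", "known", "first", "only" and "open" are said of these compounds alone.

In an ADME assay on HOS cells (Homo sapiens) for cytotoxicity (on this read-out higher numbers stand for lower toxicity in this test and lower numbers for higher toxicity in this test), three compounds have been read so far, each only as a limit of the assay:

Compound 1 `CN(Cc1nc2ccccc2n1CCN)C1CCCc2cccnc21`: > 20000 nM
Compound 2 `CN(Cc1nc2ccccc2n1CCCNC(=N)N)C1CCCc2cccnc21`: > 20000 nM
Compound 3 `CN(Cc1nc2cccc(CNCCN)c2[nH]1)C1CCCc2cccnc21`: > 20000 nM

The account follows compound 3, which offers no number to start from. Compound 3 stands at > 20000 nM, and that is a limit. The other two compounds give the same picture, (the limit of > 20000 nM in this assay, at which 3 of the 3 values shown sit).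

Compound 4 `CN(Cc1nc2cccc(N3CCNCC3)c2[nH]1)C1CCCc2cccnc21` has not yet been measured. It differs from compound 3 in one place: piperazin-1-yl in place of ((2-aminoethyl)amino)methyl on an aromatic carbon. In words, it carries piperazin-1-yl in place of ((2-aminoethyl)amino)methyl on an aromatic carbon, part of a fused system of two rings.

Among the compounds with values here, only one measured step exists, a step that the two limits leave unreadable from compound 1 to compound 2. It has no readable size, and it lies at a different place, on a saturated chain carbon. Within the data shown here, no measured step therefore speaks directly to this change, and the data give no direction for it. What remains is the plain expectation that this assay will show nothing beyond the scatter, resting on compound 3 at > 20000 nM.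

The expected size is a number no higher from compound 3 to compound 4 (the limit leaves the size open), with no direction favoured.

For compound 4 the estimated value is 20000 nM, with an expected range from 10000 nM to 40000 nM.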

Compound 4, half-maximal cytotoxic concentration: > 20000 nM
Compound 4 gave a limit, no number (the forecaster's own chance of this, stated with the estimate: 80%); the middle value lies on the limit itself.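

In this assay compound 4 stands at > 20000 nM as a limit, not a number. Within the data shown here, compound 3 also gave only a limit, so no step from compound 3 to compound 4 can be read. The compounds shown leave open how far any of them lies from that limit, and whether any change in structure alters this read-out: the limit of > 20000 nM in this assay, at which 4 of the 4 values shown sit.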